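Swapping the amine on a low-permeability compound

The compounds below may be only part of what the source reports. "The series", "measured", "known", "first", "only" and "open" are said of these compounds alone.

- compound 1 `CN(C)[C@@H]1CCN(c2cccc3c2C[C@H](CN(C)[C@H]2CCCc4cccnc42)NC3)C1`: 14 nm/s
- compound 2 `CN1CCN(Nc2cccc3c2C[C@@H](CN(C)[C@H]2CCCc4cccnc42)NC3)CC1`: 235 nm/s

In an ADME assay for permeability, using PAMPA, with a stated time of 4 h, at pH 7.4 (a higher number here means that the compound crosses the layer faster, a lower number that the compound crosses the layer more slowly), compound 1 gives 14 nm/s, the lower of the two numbers, and compound 2 gives 235 nm/s, a gap beyond the scatter. Compound 3 `CN1CC[C@H]2CN(c3cccc4c3C[C@H](CN(C)[C@H]3CCCc5cccnc53)NC4)C[C@H]21` keeps the core of compound 1 and changes only the group on an aromatic carbon of a six-membered aromatic ring of carbon only: a group of 9 heavy atoms (7 carbon, 2 nitrogen; 2 five-membered non-aromatic rings with 1 hetero atom each) in place of a group of 8 heavy atoms (6 carbon, 2 nitrogen; one five-membered non-aromatic ring with 1 hetero atom), on an aromatic carbon. The 3-(dimethylamino)pyrrolidin-1-yl group leaves, and the group that enters has no common name. Among the measured compounds shown here, no measured pair shows this change, so the expectation starts from compound 1 at 14 nm/s. The expected step is a 1.6-fold higher number from compound 1 to compound 3 (0.20 log units; within the scatter), a small rise that stays within the scatter. For compound 3 the estimated value is 22 nm/s, with an expected range of 7 nm/s to 70 nm/s.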

Compound 3, apparent permeability: 9 nm/s
Compound 3: middle estimate off by 2.4-fold (0.39 log units), on the high side; low and high end bracket the measured number.
By their numbers in this assay, from the lowest: compounds 3 and 1 (each within the scatter of the next); then compound 2.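

In this assay, the group with two five-membered non-aromatic rings in place of the 3-(dimethylamino)pyrrolidin-1-yl group gives a 1.6-fold lower number from compound 1 to compound 3 (0.19 log units; within the scatter). Among the compounds shown here, this is the first step that can be read at this aromatic carbon, and it shows that this exchange, which adds a second five-membered ring and a second defined stereocentre, leaves the two compounds indistinguishable in this read-out. No measurement available here bears on the reason for this result.

Compound 2 differs from compound 1 in more than one place, so no single change can be read from that pair. As far as these compounds go, it remains open whether a morpholine ring or an open-chain amine such as dimethylamino, on the same aromatic carbon, would give a number beyond the scatter of compound 1.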